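This account rests on a few compounds, and the source may have more. Where it says the series, first, only, none or still open, it means among the compounds named here.

Compound 1 `COCCN[C@H]1CC[C@H](Nc2cc(-c3csc(OCC4CCOCC4)n3)c(Cl)cn2)CC1` gives 570 nM in a functional assay on MV4-11 cells (Homo sapiens) for antiproliferative activity, read by CellTiter-Glo, with a stated time of 72 h; a lower number here means a stronger inhibitor of growth, a higher number a weaker inhibitor of growth.
Compound 2 `CNc1nc(-c2cc(N[C@H]3CC[C@H](NCCOC)CC3)ncc2Cl)cs1` gives 530 nM in this assay.
Compound 3 `COCCN[C@H]1CC[C@H](Nc2cc(-c3csc(NCC4CCC4)n3)c(Cl)cn2)CC1` gives > 10000 nM in this assay.

Compound 3 sits at the edge of what this assay can report: its value is a limit, not a number (the limit of > 10000 nM in this assay, at which 1 of the 3 values shown sits). Compound 1 and compound 2 lie together, since a 1.1-fold lower number from compound 1 to compound 2 (0.03 log units; within the scatter). The move to compound 3 is where the numbers change: an at least 17-fold higher number from compound 1 to compound 3 (1.24 log units; beyond the scatter), and an at least 18-fold higher number from compound 2 to compound 3 (1.27 log units; beyond the scatter). Both steps put the (cyclobutylmethyl)amino group on the weak side.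

Compound 4 `COCCN[C@H]1CC[C@H](Nc2cc(-c3csc(NCc4ccccc4)n3)c(Cl)cn2)CC1` differs from compound 3 by phenyl in place of cyclobutyl on a saturated chain carbon bound to a nitrogen on an aromatic ring. Among the compounds with values here, no measured pair here compares a cyclobutyl with a phenyl, so the two large steps into compound 3 bear on this only by showing where the starting point stands: at the limit. A benzylamino group keeps the same kind of attachment as the (cyclobutylmethyl)amino group, so no large shift in this assay is expected in either direction, and the chance that compound 4 again reports only a limit is real. Compound 4 is therefore estimated at 8000 nM, between 2500 nM and 30000 nM, which means an expected step of an at least 1.2-fold lower number from compound 3 to compound 4 (0.09 log units; that floor lies within the scatter).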

Compound 4, concentration for 50% growth inhibition: 330 nM
For compound 4 the middle estimate is 24-fold (1.38 log units) above the measured one; the whole stated range lies above it.
By their numbers in this assay, from the lowest: compounds 4, 2 and 1 (each within the scatter of the next). At a limit, above all of these: compound 3.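

In this assay, within the data shown here, the earlier compounds left open whether any ring on the saturated chain carbon bound to this nitrogen would cost growth inhibition, but phenyl in place of cyclobutyl there gives an at least 30-fold lower number from compound 3 to compound 4 (1.48 log units; beyond the scatter), so for this pair the loss goes with the cyclobutyl and not with the presence of a ring as such. Compound 3 still stands at a limit and not at a number, so the step from it has a floor and no exact size: the limit of > 10000 nM in this assay, at which 1 of the 4 values shown sits. Phenyl in place of hydrogen at the same carbon gives a 1.6-fold lower number from compound 2 to compound 4 (0.21 log units; within the scatter), and swapping the (oxan-4-yl)methoxy group for the benzylamino group gives a 1.7-fold lower number from compound 1 to compound 4 (0.24 log units; within the scatter), so both steps stay within the scatter and the phenyl brings no measurable gain over either group.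

On these data alone, whether the sharp loss is peculiar to cyclobutyl remains open, and a cyclopentyl or cyclohexyl ring on the same carbon would test that. As far as these compounds go, whether this position can give more than compound 4 also remains open, and a pyridyl ring or a phenyl ring carrying a fluorine or a methoxy group would address that question.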